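Pyridin-2-yl to pyridin-3-yl on the shared core

The compounds below may be only part of what the source reports. "The series", "measured", "known", "first", "only" and "open" are said of these compounds alone.

Measured so far:
- compound 1 `O=c1[nH]/c(=C\c2nc[nH]c2C2CC2)c(=O)[nH]/c1=C\c1cccc(Oc2ccc(F)cc2)c1`: 15.2 nM
- compound 2 `O=c1[nH]/c(=C\c2ccccn2)c(=O)[nH]/c1=C\c1cccc(Oc2ccc(F)cc2)c1`: 49.1 nM

In a functional assay on NCI-H460 cells (Homo sapiens) for cytotoxicity, read by MTT assay, with a stated time of 72 h (on this read-out higher numbers stand for weaker inhibition and lower numbers for stronger inhibition), compound 2 stands at 49.1 nM, the higher of the two numbers. The next entry is compound 3 `O=c1[nH]/c(=C\c2cccc(Oc3ccc(F)cc3)c2)c(=O)[nH]/c1=C\c1cccnc1`, which has the same atoms joined differently: pyridin-3-yl in place of pyridin-2-yl on a double-bonded chain carbon bound to an aromatic carbon. Within the data shown here, only one measured step bears on this change: a 3.2-fold higher number from compound 1 to compound 2 (0.51 log units; beyond the scatter), a modest step that exchanged 5-cyclopropyl-1H-imidazol-4-yl for pyridin-2-yl at this place. That step involved a different group, while here one pyridinyl replaces another. Among the measured compounds shown here, no measured pair yet compares pyridin-2-yl with pyridin-3-yl directly, so the direction stays open. The step expected in this assay is a 1.0-fold higher number from compound 2 to compound 3 (0.01 log units; within the scatter), with nothing expected beyond the scatter. For compound 3 the estimated value is 50 nM, with an expected range of 18 nM to 140 nM.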

Compound 3, half-maximal inhibitory concentration: > 1000 nM
Compound 3: no number, only a limit (the forecaster's own chance of this, stated with the estimate: 2%); middle value at least 20-fold (1.30 log units) away from the limit.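

For compound 3, this assay returns a limit and not a number: the limit of > 1000 nM in this assay, at which 1 of the 3 values shown sits. At this place, on a double-bonded chain carbon bound to an aromatic carbon, pyridin-2-yl and pyridin-3-yl have the same atom and hydrogen-bond counts, yet the exchange gives an at least 20-fold higher number from compound 2 to compound 3 (1.30 log units; beyond the scatter), so the read-out depends on which pyridinyl group is present and not on a pyridinyl group as such. Set against the group in compound 1, pyridin-3-yl gives an at least 65-fold higher number from compound 1 to compound 3 (1.81 log units; beyond the scatter), and both steps are lower bounds.

The compounds shown do not fix how far compound 3 lies beyond its limit. They also leave open whether pyridin-4-yl, or a pyridin-2-yl ring carrying an amine, would read closer to compound 2 or to compound 3 in this assay.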